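This account rests on a few compounds, and the source may have more. Where it says the series, first, only, none or still open, it means among the compounds named here.

Notes on the series. Compound 1 `NC(=O)/C=C1\CCc2ccc(Cl)cc21` is measured in a functional assay on the whole organism with Mus musculus as the target (on this read-out lower numbers stand for an effect already at smaller amounts and higher numbers for an effect only at larger amounts of compound), at 98 mg/kg. Compound 2 `CCN(C)C(=O)/C=C1\CCc2c(F)cc(F)cc21` gives 56 mg/kg in this assay, the lower of the two numbers available, with compound 1 the nearest of them and that gap inside the scatter. Compound 3 `Cc1cccc2c1CC/C2=C\C(N)=O` reaches only the limit of the assay, > 100 mg/kg, in this assay; one of the three results therefore sits at the limit of > 100 mg/kg in this assay, at which 1 of the 3 values shown sits. Compound 4 `CN(C)C(=O)/C=C1\CCc2c(F)cc(F)cc21` is not yet measured. It differs from compound 2 by hydrogen in place of methyl on a saturated chain carbon bound to an amide-type nitrogen. Going by the values given here, no step between measured compounds is available, so the effect of this change is not anchored by data. For compound 4 the expectation in this assay is a step of a 1.1-fold higher number from compound 2 to compound 4 (0.03 log units; within the scatter), within the scatter, and an estimated value of 60 mg/kg, from 25 mg/kg to 150 mg/kg.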

Compound 4, dose for half-maximal effect: 50 mg/kg
Compound 4: middle estimate off by 1.2-fold (0.08 log units), on the high side; low and high end bracket the measured number.
By their numbers in this assay, from the lowest: compounds 4, 2 and 1 (each within the scatter of the next). At a limit, above all of these: compound 3.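

In this assay removing the methyl gives a 1.1-fold lower number from compound 2 to compound 4 (0.05 log units; within the scatter) as the first step read in this series. At this place, on a saturated chain carbon bound to an amide-type nitrogen, ethyl(methyl)carbamoyl and dimethylcarbamoyl are not separated by this read-out. No measured property available bears on this step.

Open, on these data alone, is whether the same holds for a longer chain on the amide nitrogen, such as propyl, or for a cyclic amine such as pyrrolidine in that place. Also open, as far as these compounds go, is whether this change reads the same on the core of compound 1.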